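Swapping a Five-Membered Ring for a Bromophenyl Group

The compounds below may be only part of what the source reports. "The series", "measured", "known", "first", "only" and "open" are said of these compounds alone.

Three compounds share a common core, differing only in the group attached to the carbonyl carbon of an amide. Compound 1 `O=C(Nc1c(C(O)(C(F)(F)F)C(F)(F)F)ccc2ccccc12)C1CCC1` carries a cyclobutyl group, compound 2 `O=C(Nc1c(C(O)(C(F)(F)F)C(F)(F)F)ccc2ccccc12)C1CCCC1` a cyclopentyl group, and compound 3 `O=C(Nc1c(C(O)(C(F)(F)F)C(F)(F)F)ccc2ccccc12)c1cccc([N+](=O)[O-])c1` a 3-nitrophenyl group. In an assay on LtK cells with ATP-sensitive inward rectifier potassium channel 11 (Homo sapiens) as the target (a higher number here means that more compound is needed for the effect, a lower number that less compound is needed), compound 1 gives 45 nM, compound 2 gives 495 nM, and compound 3 gives 117 nM. Compound 2 thus has the highest number of the three, with a 4.2-fold lower number from compound 2 to compound 3 (0.63 log units; beyond the scatter) and an 11-fold higher number from compound 1 to compound 2 (1.04 log units; beyond the scatter) marking its distance from the others. The step of a 2.6-fold higher number from compound 1 to compound 3 (0.41 log units; beyond the scatter) shows that the aromatic group sits between the two rings of carbon only.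

Compound 4 `O=C(Nc1c(C(O)(C(F)(F)F)C(F)(F)F)ccc2ccccc12)c1ccc(Br)cc1` is the next step from compound 2: 4-bromophenyl in place of cyclopentyl on a carbonyl carbon. Within the data shown here, only one measured step bears directly on this, namely a 4.2-fold lower number from compound 2 to compound 3 (0.63 log units; beyond the scatter), where another six-membered aromatic ring of carbon only replaced the same cyclopentyl group and gave a modest drop. The 4-bromophenyl group is not the 3-nitrophenyl group, so the match is loose. Still, compound 4 is expected to give a lower number than compound 2, with an estimated step of a 3.3-fold lower number from compound 2 to compound 4 (0.52 log units; beyond the scatter). The estimate for compound 4 in this assay is 150 nM, within a range from 50 nM to 450 nM.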

Compound 4, half-maximal effective concentration: 47 nM
Compound 4: middle estimate off by 3.2-fold (0.50 log units), on the high side, outside the stated range (below it).
By their numbers in this assay, from the lowest: compounds 1 and 4 (each within the scatter of the next); then compound 3; then compound 2.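

In this assay, the step to the 4-bromophenyl group, an 11-fold lower number from compound 2 to compound 4 (1.02 log units; beyond the scatter), is about as large as the loss on going from cyclobutyl to cyclopentyl, an 11-fold higher number from compound 1 to compound 2 (1.04 log units; beyond the scatter), so the high number of compound 2 is not shared by every larger group at this carbonyl carbon. The two aromatic groups also differ from each other, with a 2.5-fold lower number from compound 3 to compound 4 (0.40 log units; beyond the scatter), which shows that an aromatic ring alone does not fix the number here and that what the ring carries, or where it carries it, matters as well. Meanwhile, a 1.0-fold higher number from compound 1 to compound 4 (0.02 log units; within the scatter) places the cyclobutyl and 4-bromophenyl groups within the scatter of each other, so this position gives matching numbers with two quite different groups, one a non-aromatic ring of carbon only and the other an aromatic one.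

Nothing available here explains why these groups rank as they do. Open questions are whether an unsubstituted phenyl group would behave like the 4-bromophenyl group, which would show what the bromine contributes, and where cyclohexyl or a phenyl ring bearing an amine would fall.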